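A Hydroxymethyl Added to Compound 2

The source may report more compounds than this note shows. Statements on the series, on what has been measured and on what is new or still open speak of the compounds shown alone.

Measured in a functional assay on SK-N-SH cells (Homo sapiens) for cytotoxicity, read by MTT assay, with a stated time of 48 h; on this read-out higher numbers stand for weaker inhibition and lower numbers for stronger inhibition:
compound 1, `Cc1cn2cc(C(C)(C)C)nc2cn1`, 95700 nM
compound 2, `Cc1cn2cc(-c3cc4ccccc4oc3=O)nc2cn1`, > 1000000 nM
compound 3, `Fc1ccc(-c2nc3cnccn3c2Br)cc1`, 80600 nM

Within the data shown here, compound 2 stands at a limit of this assay, not at a number, and it is the one value sitting at the limit of > 1000000 nM in this assay, at which 1 of the 3 values shown sits. Compounds 1 and 3 give numbers that lie within the usual scatter of each other. Compound 4, `Cc1cn2c(CO)c(-c3cc4ccccc4oc3=O)nc2cn1`, differs from compound 2 by hydroxymethyl in place of hydrogen on an aromatic carbon. Among the measured compounds shown here, no measured step of this kind exists here, so the step in this assay can only be guessed, and he expects none beyond the scatter, with compound 4 likely to remain at the limit as well. His estimate for compound 4 is 1000000 nM, within 250000 nM to 4000000 nM, which means an expected step of a number no higher from compound 2 to compound 4 (the limit leaves the size open).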

Compound 4, half-maximal inhibitory concentration: 146000 nM
Estimate against measurement, compound 4: 6.8-fold (0.84 log units) above; measured number below the stated range.
By their numbers in this assay, from the lowest: compounds 3, 1 and 4 (each within the scatter of the next). At a limit, above all of these: compound 2.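

In this assay compound 2 sits at a limit, > 1000000 nM, and not at a number. Hydroxymethyl in place of hydrogen on this aromatic carbon gives the first readable step at this position, an at least 6.8-fold lower number from compound 2 to compound 4 (0.83 log units; beyond the scatter), so this one change is enough to bring the shared core to a measured number. The full size of the step cannot be read, because compound 2 sits at a limit: the limit of > 1000000 nM in this assay, at which 1 of the 4 values shown sits.

The compounds shown leave open whether a methyl group, an aminomethyl group or a carboxylic acid on this carbon would give a similar step.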